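The source may report more compounds than this note shows. Statements on the series, on what has been measured and on what is new or still open speak of the compounds shown alone.

Measured in a functional assay on SMMC-7721 cells (Homo sapiens) for cytotoxicity, read by MTT assay, with a stated time of 72 h; on this read-out higher numbers stand for weaker inhibition and lower numbers for stronger inhibition:
compound 1 `O=C1C(=Cc2ccc(F)cc2)C(=O)N(c2ccc(Cl)cc2)N1c1ccc(Cl)cc1`: 23300 nM
compound 2 `COc1ccc(C=C2C(=O)N(c3ccc(Cl)cc3)N(c3ccc(Cl)cc3)C2=O)cc1`: > 128000 nM (a limit of the assay)
compound 3 `COc1ccccc1C=C1C(=O)N(c2ccc(Cl)cc2)N(c2ccc(Cl)cc2)C1=O`: 25800 nM

In this assay, compound 3 stands level with compound 1, the measured step being a 1.1-fold higher number from compound 1 to compound 3 (0.04 log units; within the scatter). Compound 2 is reported only as a limit, > 128000 nM. Both steps that involve compound 2 are large: an at least 5.4-fold higher number from compound 1 to compound 2 (0.73 log units; beyond the scatter), and an at least 4.9-fold lower number from compound 2 to compound 3 (0.69 log units; beyond the scatter).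

The next compound is compound 4 `O=C1C(=Cc2ccc(F)cc2F)C(=O)N(c2ccc(Cl)cc2)N1c1ccc(Cl)cc1`. It differs from compound 3 as follows: 2,4-difluorophenyl in place of 2-methoxyphenyl on a double-bonded chain carbon bound to a double-bonded ring carbon. Thus 2,4-difluorophenyl takes the place of 2-methoxyphenyl on the double-bonded chain carbon bound to a double-bonded ring carbon.

Among the measured compounds shown here, no measured step makes exactly this exchange. The closest is the exchange of 4-fluorophenyl for 2-methoxyphenyl, which gave a 1.1-fold higher number from compound 1 to compound 3 (0.04 log units; within the scatter), so a fluorinated phenyl and 2-methoxyphenyl have so far given matching values. The two large steps both involve 4-methoxyphenyl, a group that compound 4 does not carry. For the measured compounds named here, with only three compounds behind it, this is a thin basis, and no step beyond the scatter is expected. The expected change is a 1.2-fold lower number from compound 3 to compound 4 (0.07 log units; within the scatter). For compound 4 the estimated value is 22000 nM, with an expected range from 8000 nM to 65000 nM.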

Compound 4, half-maximal inhibitory concentration: 35800 nM
The estimate for compound 4 lay 1.6-fold (0.21 log units) below the measured number, and the stated range covers the measured number.
By their numbers in this assay, from the lowest: compounds 1, 3 and 4 (each within the scatter of the next). At a limit, above all of these: compound 2.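

In this assay, fluoro in place of hydrogen on an aromatic carbon gives a 1.5-fold higher number from compound 1 to compound 4 (0.19 log units; within the scatter), so adding this atom to the 4-fluorophenyl of compound 1 makes no difference that can be told from the scatter. With 2,4-difluorophenyl in place of 2-methoxyphenyl on the double-bonded chain carbon, the result is a 1.4-fold higher number from compound 3 to compound 4 (0.14 log units; within the scatter), so the hydrogen-bond acceptor of 2-methoxyphenyl can leave with no change beyond the scatter. The 2,4-difluorophenyl group in place of 4-methoxyphenyl gives an at least 3.5-fold lower number from compound 2 to compound 4 (0.55 log units; beyond the scatter), which sets compound 2 apart from three compounds instead of two, though the value of compound 2 is a limit and the step is known only as a bound: the limit of > 128000 nM in this assay, at which 1 of the 4 values shown sits.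

On these data alone, it remains open whether 4-methoxyphenyl is alone in this, or whether an amine, a carboxylic acid or a longer alkoxy chain on the same phenyl would also give a higher number. The compounds shown also leave open what happens to these values when either 4-chlorophenyl group of the shared core is exchanged, since all four compounds carry the same pair.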